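Chloro Added at the Far Ring of Compound 2

The compounds below may be only part of what the source reports. "The series", "measured", "known", "first", "only" and "open" are said of these compounds alone.

Compound 1 `c1ccc(-c2ccc(-c3ccc(-c4nc5ccccc5[nH]4)cc3)cc2)cc1` and compound 2 `Oc1cccc2[nH]c(-c3ccc(-c4ccc(-c5ccccc5)cc4)cc3)nc12` share a core that differs only by a hydroxy in place of hydrogen on an aromatic carbon. In a functional assay on A2780 cells (Homo sapiens) for inhibition, read by sulforhodamine B assay (a higher number here means a weaker inhibitor of growth, a lower number a stronger inhibitor of growth), compound 1 gives 32100 nM, and in this assay compound 2 gives 41000 nM. The step of a 1.3-fold higher number from compound 1 to compound 2 (0.11 log units; within the scatter) shows that this exchange left the growth inhibition essentially unchanged. Compound 2 thus stands with the higher of the two numbers, but its gap to compound 1 lies within the scatter, so no order between them can be claimed.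

Compound 3 `Oc1cccc2[nH]c(-c3ccc(-c4ccc(-c5cccc(Cl)c5)cc4)cc3)nc12` differs from compound 2 in one place: chloro in place of hydrogen on an aromatic carbon. For the measured compounds named here, no measured step involves a chloro group, so the only comparison available, a 1.3-fold higher number from compound 1 to compound 2 (0.11 log units; within the scatter), concerns a different substituent and bears on this change only by showing that a single small change on a peripheral ring did little. Compound 3 is therefore expected to give a number close to compound 2, with a 1.2-fold lower number from compound 2 to compound 3 (0.07 log units; within the scatter) as the estimated step. Compound 3 is estimated at 35000 nM in this assay, with a range from 12000 nM to 100000 nM.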

Compound 3, concentration for 50% growth inhibition: 2800 nM
Compound 3: middle estimate off by 13-fold (1.10 log units), on the high side, and the stated range ends above it.
By their numbers in this assay, from the lowest: compound 3; then compounds 1 and 2 (each within the scatter of the next).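

In this assay the exchange of phenyl for 3-chlorophenyl gives a 15-fold lower number from compound 2 to compound 3 (1.17 log units; beyond the scatter) and thus counts as a large step, so this one position on a six-membered aromatic ring of carbon only, meta to a large group, proves far more sensitive than the earlier comparison suggested. The hydroxy exchange had given only a 1.3-fold higher number from compound 1 to compound 2 (0.11 log units; within the scatter) and left no order between its two compounds, whereas a single chlorine atom here separates compound 3 clearly from compound 2. The data therefore show that a small change on this peripheral ring can strongly alter growth inhibition, but nothing available explains why this change does so.

The compounds shown leave open whether fluoro, methyl, methoxy or an amine in the same place would give a step of similar size, and whether chloro elsewhere on this ring would do the same. They also leave open whether the step depends on the hydroxy carried by both compound 2 and compound 3, as the chloro group appears here only alongside that hydroxy.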